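The source may hold more compounds than are shown below. What is called first, only, known or untested is meant among the compounds shown, and "the series" means these compounds.

Measured so far:
compound 1, `O=C(NCc1ccc(S(=O)(=O)c2ccccc2)cc1)c1nc2cnccc2[nH]1`, which in an assay for inhibition of Nicotinamide phosphoribosyltransferase (Homo sapiens), read by mass spectrometry, with stated times of 15 min and 30 min (a lower number here means a stronger inhibitor, a higher number a weaker inhibitor), gives 7100 nM;
compound 2, `O=C(NCc1ccc(S(=O)(=O)c2ccccc2)cc1)c1cc2ncccc2s1`, which in this assay gives 400 nM.

Within the data shown here, compound 2 has the lowest number of the two in this assay; its nearest neighbour is compound 1, and the only step known here, an 18-fold lower number from compound 1 to compound 2 (1.25 log units; beyond the scatter), separates them. Compound 3, `O=C(NCc1ccc(S(=O)(=O)c2ccccc2)cc1)c1nc2ccncc2s1`, is not yet measured. It differs from compound 2 in one place: a group of 9 heavy atoms (6 carbon, 2 nitrogen, 1 sulfur; one five-membered aromatic ring with 2 hetero atoms, one six-membered aromatic ring with 1 hetero atom) in place of a group of 9 heavy atoms (7 carbon, 1 nitrogen, 1 sulfur; one five-membered aromatic ring with 1 hetero atom, one six-membered aromatic ring with 1 hetero atom), on a carbonyl carbon. The entering group keeps the sulfur of compound 2 while bringing a second hetero atom into the five-membered ring, as the group of compound 1 has. Among the measured compounds shown here, the one step that bears on this, an 18-fold lower number from compound 1 to compound 2 (1.25 log units; beyond the scatter), was large, but no step from compound 2 to a group with a sulfur and an extra nitrogen is known. A step of modest size, towards a higher number, is therefore expected in this assay for compound 3, a 1.5-fold higher number from compound 2 to compound 3 (0.18 log units; within the scatter), with compound 3 estimated at 600 nM, within a range of 200 nM to 2000 nM.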

Compound 3, half-maximal inhibitory concentration: 210 nM
The estimate for compound 3 lay 2.9-fold (0.46 log units) above the measured number, and the stated range covers the measured number.
By their numbers in this assay, from the lowest: compounds 3 and 2 (each within the scatter of the next); then compound 1.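

In this assay the change from compound 2 gives a 1.9-fold lower number from compound 2 to compound 3 (0.28 log units; within the scatter) and so adds a second hetero atom to the five-membered ring, with the sulfur kept, without moving the number beyond the scatter. The comparison with the group of compound 1, which also has two hetero atoms in that ring, gives a 34-fold lower number from compound 1 to compound 3 (1.53 log units; beyond the scatter) and shows that two hetero atoms in the five-membered ring do not by themselves go with the high number of compound 1. Nothing measured here accounts for these differences.

The compounds shown leave open whether an oxygen in the five-membered ring, in place of the sulfur, would give a number like that of compound 1 or like those of compound 2 and compound 3. They also do not tell what a six-membered ring of carbon alone would do to the number.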